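Sulfonamide ring swap on the thiourea series: oxazole to pyrimidine

The compounds below may be only part of what the source reports. "The series", "measured", "known", "first", "only" and "open" are said of these compounds alone.

Three compounds carry the shared core with a sulfonamide on one side. Compound 1 `O=C(Nc1ccccc1)Nc1ccc(S(=O)(=O)Nc2ccnc3cc(C(F)(F)F)ccc23)cc1` has an unsubstituted phenyl on the sulfonamide nitrogen; in a functional assay on MDA-MB-231 cells (Homo sapiens) for antiproliferative activity, read by sulforhodamine B assay, with a stated time of 48 h (a higher number here means a weaker inhibitor, a lower number a stronger inhibitor), compound 1 gives 52900 nM. Compound 2 `Cc1noc(NS(=O)(=O)c2ccc(N/C(S)=N\c3ccnc4cc(C(F)(F)F)ccc34)cc2)c1C` carries the 3,4-dimethyl-1,2-oxazol-5-yl group there, and in this assay compound 2 gives 27900 nM. Compound 3 `Cc1ccnc(NS(=O)(=O)c2ccc(N/C(S)=N\c3ccnc4cc(C(F)(F)F)ccc34)cc2)n1` carries the 4-methylpyrimidin-2-yl group, and in this assay compound 3 gives 29800 nM. Compound 2 holds the lowest of the three numbers, yet neither gap to it reaches beyond the scatter: the step of a 1.1-fold higher number from compound 2 to compound 3 (0.03 log units; within the scatter) is flat, and the values of compound 1 and compound 2 differ by no more than the scatter either.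

Compound 4 `Cc1cc(C)nc(NS(=O)(=O)c2ccc(N/C(S)=N\c3ccnc4cc(C(F)(F)F)ccc34)cc2)n1` is the next member. The change from compound 2 is 4,6-dimethylpyrimidin-2-yl in place of 3,4-dimethyl-1,2-oxazol-5-yl on a sulfonamide nitrogen. Among the measured compounds shown here, the one step that bears on it, a 1.1-fold higher number from compound 2 to compound 3 (0.03 log units; within the scatter), swaps the same oxazole for a pyrimidine carrying one methyl and produces no movement in this assay; compound 4 adds a second methyl on that pyrimidine. For the measured compounds named here, no measured step shows what a second methyl does here. The expectation is therefore no step beyond the scatter, i.e. a 1.0-fold higher number from compound 2 to compound 4 (0.02 log units; within the scatter) is estimated to be flat. For compound 4 the estimate in this assay is 29000 nM, with a range from 14000 nM to 60000 nM.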

Compound 4, half-maximal inhibitory concentration: 52900 nM
Compound 4: middle estimate off by 1.8-fold (0.26 log units), on the low side, within the range that was stated.
By their numbers in this assay, from the lowest: compounds 2, 3, 1 and 4 (each within the scatter of the next).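

In this assay, the step that isolates the second methyl, methyl in place of hydrogen on an aromatic carbon, reads (a 1.8-fold higher number from compound 3 to compound 4 (0.25 log units; within the scatter)). Among the compounds shown here, this is the first direct reading of that change on the pyrimidine, and it does not separate compound 3 from compound 4. The whole exchange of 3,4-dimethyl-1,2-oxazol-5-yl for 4,6-dimethylpyrimidin-2-yl on the sulfonamide nitrogen reads (a 1.9-fold higher number from compound 2 to compound 4 (0.28 log units; within the scatter)), so this place now tolerates the five-membered ring and both methylated six-membered rings in compounds 2, 3 and 4 without a step beyond the scatter. No measurement at hand offers an explanation for these readings.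

Still open is whether any group on the sulfonamide nitrogen can move the number beyond the scatter, since the steps read so far among these compounds all stay within it. An amine or a carboxylic acid in place of a methyl on the pyrimidine, or a longer chain such as propyl there, would test whether this place responds at all.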